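The source may hold more compounds than are shown below. What is called first, only, known or untested is meant among the compounds shown, and "the series" means these compounds.

Compound 3 `COC(=O)N1CCN(C(=O)c2nc(Nc3cc(C4CC4)[nH]n3)c3cc(Cl)ccc3n2)C[C@H]1C` stands highest of the three measured compounds in an assay for inhibition of serine/threonine-protein kinase PAK 4 (Homo sapiens), read by FRET and Z'-LYTE, with a stated time of 60 min, tested at 5 uM, in the presence of a further agent that is not named here (a higher number here means a stronger effect of the compound at the concentration tested, a lower number a weaker effect), where compound 3 gives 89.6%. Compound 1 `CC(C)COC(=O)N1CCN(C(=O)c2nc(Nc3cc(C4CC4)[nH]n3)c3cc(Cl)ccc3n2)C[C@H]1C` gives 30.7% and compound 2 `C[C@@H]1CN(C(=O)c2nc(Nc3cc(C4CC4)[nH]n3)c3cc(Cl)ccc3n2)CCN1C(=O)OC(C)(C)C` gives 22.7%, both well apart from compound 3. Compound 4 `CCOC(=O)N1CCN(C(=O)c2nc(Nc3cc(C4CC4)[nH]n3)c3cc(Cl)ccc3n2)C[C@H]1C` differs from compound 3 by methyl in place of hydrogen on a saturated chain carbon bound to an oxygen next to a carbonyl group, methoxycarbonyl to ethoxycarbonyl. Among the measured compounds shown here, two measured steps bear on this, and both run toward smaller groups on the oxygen next to the carbonyl group: hydrogen in place of isopropyl gave a number 58.9 percentage points higher from compound 1 to compound 3 (beyond the scatter), and methyl in place of tert-butyl gave a number 66.9 percentage points higher from compound 2 to compound 3 (beyond the scatter). A single entering methyl is a smaller change than either, so a moderate fall in this assay is expected, a number 19.6 percentage points lower from compound 3 to compound 4 (beyond the scatter). Compound 4 is therefore estimated at 70%, with a range from 45% to 90%.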

Compound 4, a percentage reported as inhibition, at one concentration (the size of the read-out at that concentration, not a potency): 79.2%
For compound 4 the middle estimate is 9.2 percentage points below the measured one; the measured number falls inside the stated range.
By their numbers in this assay, from the lowest: compounds 2 and 1 (each within the scatter of the next); then compound 4; then compound 3.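

Ethoxycarbonyl keeps most of the effect in this assay: the change from methoxycarbonyl gives a number 10.4 percentage points lower from compound 3 to compound 4 (beyond the scatter) as a modest step. The large fall therefore does not come with the first added carbon, since ethyl in place of tert-butyl gives a number 56.5 percentage points higher from compound 2 to compound 4 (beyond the scatter) and methyl in place of isopropyl gives a number 48.5 percentage points higher from compound 1 to compound 4 (beyond the scatter) on the same chain. Most of the loss thus lies between ethyl and the isobutyl and tert-butyl groups, and nothing given here accounts for it. The compounds shown leave open how an n-propyl or isopropyl group would read at this oxygen, which would place the fall more closely. From the compounds shown here alone, a methoxyethyl chain or a cyclopropylmethyl group there also remains open.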